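The compounds below may be only part of what the source reports. "The series", "measured", "known", "first", "only" and "open" are said of these compounds alone.

Compound 1 `CC(C)(C)C1=NN(c2ccc(Br)cc2)C(c2ccc(O)cc2)C1` is one of three compounds that have been tested in an assay on isolated protein for inhibition of protein kinase C zeta type (Homo sapiens), with a stated time of 4 min, tested at 62.5 uM; on this read-out lower numbers stand for less inhibition and higher numbers for more inhibition at the one concentration tested (going by the name of the read-out). In this assay compound 1 gives 93.2%. Compound 3 `Oc1ccc(C2CC(c3cccs3)=NN2c2ccc(Br)cc2)cc1` gives 95.2%, and the step of a number 2 percentage points higher from compound 1 to compound 3 (within the scatter) lies within the scatter. Among the compounds with values here, compound 2 `CCOc1ccccc1C1=NN(c2ccc(Cl)cc2)C(c2ccc(O)cc2)C1` gives 42.8%, a number well below that of compound 1, beyond the scatter; compound 2 differs from compound 1 in more than one place, so no single step is drawn from it. Compound 1 thus stands second highest of the three, close to compound 3 and far above compound 2.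

Compound 4 `CC(C)(C)C1=NN(c2ccc(O)cc2)C(c2ccc(O)cc2)C1` has not yet been measured. It differs from compound 1 in one place: hydroxy in place of bromo on an aromatic carbon. Within the data shown here, none of the measured steps bears on this change. The step from compound 1 to compound 3 alters the group on a carbon with a double bond to nitrogen, not the group on the aromatic ring that carries the bromo, and compound 2 changes two places at once. There is therefore no measured guide for the size or direction of the step.

In this assay compound 4 is expected to give about 78%, in the range 40% to 97%. Among the measured compounds shown here, the expected step of a number 15.2 percentage points lower from compound 1 to compound 4 (beyond the scatter) is small, but it is given a wide range because no measured step bears on this change.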

Compound 4, a percentage reported as inhibition, at one concentration (the size of the read-out at that concentration, not a potency): 40.9%
Estimate against measurement, compound 4: 37.1 percentage points above; low and high end bracket the measured number.
By their numbers in this assay, from the lowest: compounds 4 and 2 (each within the scatter of the next); then compounds 1 and 3 (each within the scatter of the next).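

In this assay, hydroxy in place of bromo on the aromatic carbon para to a large group gives a clear drop, a number 52.3 percentage points lower from compound 1 to compound 4 (beyond the scatter), so this place on the ring is sensitive to which group it carries. Within the data shown here, the only single change measured before lay elsewhere in the molecule, thiophen-2-yl in place of tert-butyl, and that step, a number 2 percentage points higher from compound 1 to compound 3 (within the scatter), gave no sign that a one-group change could alter the read-out so much; the 4-bromophenyl to 4-hydroxyphenyl change now shows that one can, even though only one heavy atom is exchanged for another. Nothing measured here explains why this exchange has such an effect.

With a single replacement at this place, the compounds shown cannot separate what is lost with the bromo from what the hydroxy brings, and a methoxy group or an amine at the same carbon would help to tell these apart. They also leave open whether the same exchange would have a step of similar size in a compound carrying thiophen-2-yl instead of tert-butyl.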